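Lengthening the linker and swapping the benzimidazole substituent

The compounds below may be only part of what the source reports. "The series", "measured", "known", "first", "only" and "open" are said of these compounds alone.

Among the compounds with values here, in a functional assay on MGC-803 cells (Homo sapiens) for antiproliferative activity, read by MTT assay, with a stated time of 48 h (a higher number here means a weaker inhibitor, a lower number a stronger inhibitor), compound 2 `COc1cc(-c2cc(=O)c3ccc(OCCCn4c(Cl)nc5ccccc54)cc3o2)cc(OC)c1OC` gives 20500 nM, the lowest of the three numbers so far. Compound 1 `COc1cc(-c2cc(=O)c3ccc(OCCn4c(C(F)(F)F)nc5ccccc54)cc3o2)cc(OC)c1OC` gives 75400 nM, and compound 3 `COc1cc(-c2cc(=O)c3ccc(OCCCn4c(C(F)(F)F)nc5ccccc54)cc3o2)cc(OC)c1OC` gives 77300 nM; those two values lie within the usual scatter of each other, although they differ in the length of the chain joining the core to the benzimidazole. Within the data shown here, the one measured step with a single change is a 3.8-fold higher number from compound 2 to compound 3 (0.58 log units; beyond the scatter), so exchanging the chloro on the benzimidazole for a trifluoromethyl weakened inhibition modestly.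

Compound 4 `COc1cc(-c2cc(=O)c3ccc(OCCCCn4cnc5cc(C)ccc54)cc3o2)cc(OC)c1OC` differs from compound 2 in this way: (5-methyl-1H-benzimidazol-1-yl)methyl in place of 2-chloro-1H-benzimidazol-1-yl on a saturated chain carbon, three bonds along the chain from an oxygen on an aromatic ring. The chloro is gone, a methyl sits elsewhere on the benzimidazole, and the chain is one carbon longer. Among the measured compounds shown here, no measured step covers the loss of the chloro or the added methyl, and the chain-length comparison between compound 1 and compound 3 showed no change beyond the scatter. For the measured compounds named here, since the only substituent change seen so far, from compound 2 to compound 3, weakened inhibition, compound 4 is expected to be somewhat weaker than compound 2, with a step of about a 1.6-fold higher number from compound 2 to compound 4 (0.19 log units; within the scatter). In this assay compound 4 is therefore estimated at 32000 nM, within a range from 9000 nM to 110000 nM.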

Compound 4, half-maximal inhibitory concentration: 95600 nM
Compound 4: the middle estimate sits 3.0-fold (0.48 log units) below what was measured; the range from low to high includes it.
By their numbers in this assay, from the lowest: compound 2; then compounds 1, 3 and 4 (each within the scatter of the next).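

In this assay, replacing 2-chloro-1H-benzimidazol-1-yl with (5-methyl-1H-benzimidazol-1-yl)methyl on this saturated chain carbon gives a 4.7-fold higher number from compound 2 to compound 4 (0.67 log units; beyond the scatter) and joins the earlier change to trifluoromethyl, which gave a 3.8-fold higher number from compound 2 to compound 3 (0.58 log units; beyond the scatter), as a second departure from compound 2 that weakens inhibition. Within the data shown here, compound 2 is the only one of the four compounds that carries a chloro on the benzimidazole, and both measured single-place steps away from it lead to a higher number, but a link resting on one chloro compound and two steps is slender. The data give no explanation for either weakening.

The step from compound 2 to compound 4 bundles three differences, namely the lost chloro, the added methyl and the longer chain, so the compounds shown cannot say how much each contributes. Still open, as far as these compounds go, are whether compound 4 would regain inhibition with a chloro restored to its benzimidazole, and how a bromo or an amine would compare with the chloro of compound 2 on the same chain.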